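A Urea Becomes a Benzamide on the Shared Core

The source may hold more compounds than are shown below. What is called first, only, known or untested is meant among the compounds shown, and "the series" means these compounds.

Compound 2 `COc1cc(-c2nn(-c3cccc(NC(=O)Nc4cccc(C(F)(F)F)c4)c3)cc2-c2ccncc2)ccc1Cl` gives 1370 nM in a functional assay on U-251 cells (Homo sapiens) for inhibition, read by sulforhodamine B assay, with a stated time of 48 h; on this read-out higher numbers stand for weaker inhibition of growth and lower numbers for stronger inhibition of growth. It stands level with compound 1 `COc1cc(-c2nn(-c3cccc(NC(=O)Nc4cc(C(F)(F)F)cc(C(F)(F)F)c4)c3)cc2-c2ccncc2)ccc1Cl`, which gives 1370 nM, and the two together carry the highest numbers of the three; compound 3 `O=C(Nc1cccc(-n2cc(-c3ccncc3)c(-c3ccc(Cl)c(O)c3)n2)c1)Nc1cc(C(F)(F)F)cc(C(F)(F)F)c1` gives 1170 nM. Both measured steps were small: no change at the digits printed from compound 1 to compound 2 (within the scatter) and a 1.2-fold lower number from compound 1 to compound 3 (0.07 log units; within the scatter). Compound 4 `COc1cc(-c2nn(-c3cccc(NC(=O)c4ccccc4)c3)cc2-c2ccncc2)ccc1Cl` carries the change (phenyl in place of (3-(trifluoromethyl)phenyl)amino on a carbonyl carbon). Among the measured compounds shown here, neither measured step altered that carbonyl or its attached nitrogen, so no step bears directly on this change; the steps show only that changes elsewhere left this assay unmoved. For compound 4 a somewhat higher number is expected, a step of a 2.2-fold higher number from compound 2 to compound 4 (0.34 log units; beyond the scatter), giving an estimate of 3000 nM with a range from 1000 nM to 10000 nM.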

Compound 4, concentration for total growth inhibition: 30800 nM
For compound 4 the middle estimate is 10-fold (1.01 log units) below the measured one, and the stated range ends below it.
By their numbers in this assay, from the lowest: compounds 3, 1 and 2 (each within the scatter of the next); then compound 4.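

Earlier steps elsewhere on the molecule left the numbers in this assay within the scatter, but the group on this carbonyl carbon matters far more: a 22-fold higher number from compound 2 to compound 4 (1.35 log units; beyond the scatter), meaning much weaker inhibition of growth. The change removes the amino nitrogen with its hydrogen-bond donor and the trifluoromethyl together, so this one step cannot separate them. Nothing measured here accounts for its size. Still open, from the compounds shown here alone, is which part counts: phenylamino on the carbonyl carbon, or a trifluoromethyl-bearing phenyl attached directly to it, would pull the two apart.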